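A few compounds are considered here, and "the series" means these few. Any claim that something is new, unique, unknown or untested is made for them only; others in the source may bear on it.

Measured compounds in a functional assay on HepG2 cells (Homo sapiens) for inhibition, read by MTT assay, with a stated time of 48 h, tested at 10 uM; on this read-out lower numbers stand for less inhibition of growth and higher numbers for more inhibition of growth at the one concentration tested:

compound 1 `C#CCOc1ccc(/C=C/C(=O)c2ccc(Br)cc2)cc1` gives 22%
compound 2 `O=C(/C=C/c1ccc(OCc2cn(Cc3cccc(Br)c3)nn2)cc1)c1ccc(Br)cc1` gives 25%
compound 3 `O=C(/C=C/c1ccc(OCc2cn(Cc3ccc(Br)cc3)nn2)cc1)c1ccc(Br)cc1` gives 22%

Compound 3 stands level with compound 1 at the digits shown, the two together the lowest of the three numbers; its gap to compound 2 is within the scatter. Among the compounds with values here, the one step between neighbours, a number 3 percentage points lower from compound 2 to compound 3 (within the scatter), concerns the bromophenyl on the saturated chain carbon bound to the aromatic nitrogen and lies within the scatter.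

Compound 4 `O=C(/C=C/c1ccc(OCc2cn(Cc3ccc(F)cc3)nn2)cc1)c1ccc(Br)cc1` differs from compound 3 in one place: fluoro in place of bromo on an aromatic carbon. Within the data shown here, no measured pair covers an exchange of one halogen for another, so the only guidance is that the single measured step in this assay, from compound 2 to compound 3, was within the scatter, and that all three numbers sit close together. A step of no more than the scatter is therefore expected in this assay, in no particular direction, and the estimated step of no change at the digits printed from compound 3 to compound 4 (within the scatter) is taken as essentially flat. Compound 4 is thus expected at about 22%, between 12% and 33%.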

Compound 4, percent growth inhibition at one concentration: 22%
Estimate against measurement, compound 4: no gap at the digits printed; the range from low to high includes it.
By their numbers in this assay, from the lowest: compounds 1, 3, 4 and 2 (each within the scatter of the next).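

In this assay, within the data shown here, the exchange of bromo for fluoro, on an aromatic carbon para to a large group, gives no change at the digits printed from compound 3 to compound 4 (within the scatter): this is the first halogen exchange at this place, and the read-out does not respond to it. The wider change of 4-fluorophenyl in place of 3-bromophenyl gives a number 3 percentage points lower from compound 2 to compound 4 (within the scatter), so altering the halogen and its place together also stays inside the scatter. Nothing available explains this flat behaviour.

On these data alone, with only bromo and fluoro on this ring, it remains open whether an amine, a carboxylic acid or a methoxy group at the same carbon would move the number. As far as these compounds go, it also remains open whether any change to this benzyl group can shift growth inhibition beyond the scatter.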